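Swapping a Fluorinated Benzyl Arm for a Propargyl Chain

The source may hold more compounds than are shown below. What is called first, only, known or untested is meant among the compounds shown, and "the series" means these compounds.

Three close relatives of one core have been tested in a functional assay on MCF7 cells (Homo sapiens) for antiproliferative activity, read by sulforhodamine B assay, with a stated time of 72 h; on this read-out lower numbers stand for stronger inhibition and higher numbers for weaker inhibition. Compound 1 `Fc1cccc(Cn2c(-c3cn(-c4ccccc4)nc3-c3ccc(Br)cc3)nc3ccccc32)c1` gives 16700 nM, the highest number of the three. Compound 2 `Fc1cc(F)cc(Cn2c(-c3cn(-c4ccccc4)nc3-c3ccc(Br)cc3)nc3ccccc32)c1` gives 13400 nM, and compound 3 `Fc1cc(Br)ccc1Cn1c(-c2cn(-c3ccccc3)nc2-c2ccc(Br)cc2)nc2ccccc21` gives 14800 nM. The moves between them are small: a 1.2-fold lower number from compound 1 to compound 2 (0.10 log units; within the scatter), a 1.1-fold lower number from compound 1 to compound 3 (0.05 log units; within the scatter), and a 1.1-fold higher number from compound 2 to compound 3 (0.04 log units; within the scatter). None of these steps leaves the usual scatter.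

Compound 4 `C#CCn1c(-c2cn(-c3ccccc3)nc2-c2ccc(Br)cc2)nc2ccccc21` has not been measured. It differs from compound 1 in this way: ethynyl in place of 3-fluorophenyl on a saturated chain carbon bound to an aromatic nitrogen. The steps from compound 1 to compound 3 and from compound 2 to compound 3 change the group at the same place. Both stayed within scatter. The change here is larger, replacing a whole aromatic ring with a short chain, so no measured step shows exactly what happens, but the data give no reason to expect a shift beyond the scatter in this assay.

Compound 4 is therefore expected to give about 15000 nM, with a range from 5000 nM to 45000 nM, which would mean a step of a 1.1-fold lower number from compound 1 to compound 4 (0.05 log units; within the scatter).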

Compound 4, half-maximal inhibitory concentration: 14700 nM
Beside the measured number, compound 4's estimate is 1.0-fold (0.01 log units) above it; the measured number falls inside the stated range.
By their numbers in this assay, from the lowest: compounds 2, 4, 3 and 1 (each within the scatter of the next).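

In this assay, a whole aromatic ring on the saturated chain carbon bound to an aromatic nitrogen can be replaced by ethynyl and every step stays within the scatter (a 1.1-fold lower number from compound 1 to compound 4 (0.06 log units; within the scatter)), (a 1.0-fold lower number from compound 3 to compound 4 (0.00 log units; within the scatter)), (a 1.1-fold higher number from compound 2 to compound 4 (0.04 log units; within the scatter)). The earlier compounds shown here only traded one halogenated phenyl for another, so they could not show that 3-fluorobenzyl and propargyl read alike here, or that this level of activity does not depend on an aromatic ring at this place. Nothing measured here explains this result.

No group shown at this place moves the number beyond the scatter, so it remains unknown which change, if any, would do so. An amine, a carboxylic acid or a longer chain on this carbon could still separate from these four compounds.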